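The compounds below may be only part of what the source reports. "The series", "measured", "known", "first", "only" and "open" are said of these compounds alone.

Compound 1 `CCOc1cc(-c2ccccc2)nc2ccccc12`: > 10 ug/mL
Compound 2 `c1ccc(COc2cc(-c3ccccc3)nc3ccccc23)cc1`: > 10 ug/mL

Both readings come from a functional assay on L1210 (1565) cells (Mus musculus) for cytotoxicity; on this read-out lower numbers stand for an effect already at smaller amounts and higher numbers for an effect only at larger amounts of compound. In this test, compound 2 gives > 10 ug/mL, which is a limit and not a number. Compound 3 `CC(C)Oc1cc(-c2ccccc2)nc2ccccc12` is still unmeasured and differs from compound 2 on an oxygen on an aromatic ring: isopropyl in place of benzyl on an oxygen on an aromatic ring. Among the compounds with values here, the only measured step that bears on this is a step that the two limits leave unreadable from compound 1 to compound 2. As far as these compounds go, its size is unknown, since the limit of > 10 ug/mL in this assay, at which 2 of the 2 values shown sit, holds both compounds, so no step in either direction can be expected with confidence. The expected step is a step that the limit leaves unreadable from compound 2 to compound 3, with no direction to be read from the data. Compound 3 is estimated at 15 ug/mL, with an expected range of 7 ug/mL to 40 ug/mL.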

Compound 3, half-maximal effective concentration: > 10 ug/mL
Compound 3: no number, only a limit; the forecaster's own chance of this, stated with the estimate: 85%; the middle value does not contradict the limit.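

No step can be read between compound 1, compound 2 and compound 3, since each gives a limit and not a number: the limit of > 10 ug/mL in this assay, at which 3 of the 3 values shown sit.

As far as these compounds go, how far apart these three compounds truly lie in this assay stays open, as does whether any group on the oxygen brings a measurable effect.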